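Cytotoxicity of Piperidinyl Sulfonamides: an Azepane Replacement

The source may hold more compounds than are shown below. What is called first, only, known or untested is meant among the compounds shown, and "the series" means these compounds.

Measured so far:
- Compound 1, `Cc1cc(C)c(S(=O)(=O)N2CCC(N3CCC(CCO)CC3)CC2)c(C)c1`: > 5000 nM
- Compound 2, `CC(=O)Nc1ccc(S(=O)(=O)N2CCC(N3CCC(C)CC3)CC2)c2ccccc12`: > 10000 nM
- Compound 3, `CC1CCN(C2CCN(S(=O)(=O)c3nccn3C)CC2)CC1`: > 10000 nM

Three sulfonamides built on a shared core have been tested in an ADME assay on HCT-116 cells (Homo sapiens) for cytotoxicity, read by CellTiter-Glo, with a stated time of 72 h; on this read-out lower numbers stand for stronger inhibition and higher numbers for weaker inhibition. None of the three gave a number. Compound 1 sits at a limit of the assay, > 5000 nM. Compound 2 sits at a limit of the assay, > 10000 nM. Compound 3 also sits at a limit of the assay, > 10000 nM. So compound 1 stands where the others do: its value is a limit, (the limit of > 5000 nM in this assay, at which 1 of the 3 values shown sits), while the other two values are a limit too, (the limit of > 10000 nM in this assay, at which 2 of the 3 values shown sit). Among the measured compounds shown here, no step between two measured compounds can be read from such limits.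

Compound 4, `Cc1cc(C)c(S(=O)(=O)N2CCC(N3CCCCCC3)CC2)c(C)c1`, is the next compound to be measured. It differs from compound 1 in one place: azepan-1-yl in place of 4-(2-hydroxyethyl)piperidin-1-yl on a saturated ring carbon. A change of this kind, on a ring that is shared by all three measured compounds, gives no reason to expect compound 4 to leave the region where compound 1 sits. The step that the limit leaves unreadable from compound 1 to compound 4 is expected to be none beyond the scatter. Compound 4 is therefore estimated at 10000 nM, within a range from 3000 nM to 40000 nM, with the most likely outcome being another limit rather than a number.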

Compound 4, half-maximal inhibitory concentration: > 5000 nM
Compound 4 was reported as a limit; the forecaster's own chance of this, stated with the estimate: 80%; the middle value is on the limit's open side.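

No step from compound 1 to compound 4 can be read, since both results in this assay are limits and not numbers: the limit of > 5000 nM in this assay, at which 2 of the 4 values shown sit.

The compounds shown leave open whether any of them reaches a measurable half-maximal inhibitory concentration in this assay, and so how azepan-1-yl compares with 4-(2-hydroxyethyl)piperidin-1-yl.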